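The source may hold more compounds than are shown below. What is called first, only, known or untested is meant among the compounds shown, and "the series" means these compounds.

Compound 1 `O=C(O)c1cc(-c2cocn2)ccc1O` is the reference point of this small series. Among the compounds with values here, in a functional assay on the whole organism for inhibition, with Rattus norvegicus as the target, read by paw edema (a lower number here means that less compound is needed, a higher number that more compound is needed for the effect), compound 1 gives 110 mg/kg, the lowest of the two numbers measured so far. Its closest neighbour is compound 2 `O=C(O)c1cc(-n2nccn2)ccc1O`, which in this assay gives 150 mg/kg; the step of a 1.4-fold higher number from compound 1 to compound 2 (0.13 log units; within the scatter) stays within the scatter, so the two cannot be ordered.

Compound 3 `O=C(O)c1cc(-c2csnn2)ccc1O` has not yet been measured in this assay. Relative to compound 1 the change is 1,2,3-thiadiazol-4-yl in place of 1,3-oxazol-4-yl on an aromatic carbon. Within the data shown here, the only measured step that bears on it is the one from compound 1 to compound 2, which also exchanges one five-membered aromatic ring for another at the same position and was within the scatter. Nothing indicates a step beyond the scatter for compound 3 either, in either direction. Compound 3 is therefore expected to give about 130 mg/kg in this assay, with a range of 60 mg/kg to 280 mg/kg; the expected step is a 1.2-fold higher number from compound 1 to compound 3 (0.07 log units; within the scatter).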

Compound 3, dose for half-maximal effect: > 200 mg/kg
Compound 3 gave a limit, no number; the forecaster's own chance of this, stated with the estimate: 10%; middle value at least 1.5-fold (0.18 log units) from the limit.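

In this assay compound 3 gives a limit and not a number: the limit of > 200 mg/kg in this assay, at which 1 of the 3 values shown sits. The step readings are an at least 1.8-fold higher number from compound 1 to compound 3 (0.25 log units; that floor lies within the scatter) and an at least 1.3-fold higher number from compound 2 to compound 3 (0.12 log units; that floor lies within the scatter), so at this position, para to a hydroxy group and meta to a carboxy group, 1,2,3-thiadiazol-4-yl cannot yet be ordered against either of the other two rings. The new finding is narrower: exchanging one five-membered aromatic ring for another here can end in a limit, which the first two compounds, both with numbers, did not show.

As far as these compounds go, the true size of both steps to compound 3 remains open. So does the outcome in this assay for a non-ring group at this place, such as an amine or an amide.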